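The source may hold more compounds than are shown below. What is called first, only, known or untested is meant among the compounds shown, and "the series" means these compounds.

Compound 1, `N#C/C(=C/c1ccc2ccccc2c1)C(=O)c1ccc[nH]1`: < 10000 nM
Compound 2, `Cc1ccc(/C=C(/C#N)C(=O)c2ccc[nH]2)cc1`: 19000 nM

Of the compounds shown here, two sharing the core of compound 2 have been tested in a functional assay on A2780 cells (Homo sapiens) for cytotoxicity, read by MTT assay, with a stated time of 72 h; on this read-out lower numbers stand for stronger inhibition of growth and higher numbers for weaker inhibition of growth. For compound 1 the value < 10000 nM is a limit of the assay and not a number. In this assay, within the data shown here, compound 2 gives 19000 nM, which is the only plain number in the set. The other entry, that of compound 1, is a limit (the limit of < 10000 nM in this assay, at which 1 of the 2 values shown sits). Among the measured compounds shown here, no step between two measured compounds is known here, so nothing measured so far shows how a change on the six-membered aromatic ring of carbon only shifts growth inhibition in this assay.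

Compound 3, `N#C/C(=C/c1ccc(Cl)cc1)C(=O)c1ccc[nH]1`, has not yet been measured. It differs from compound 2 by chloro in place of methyl on an aromatic carbon. For the measured compounds named here, since the measured data hold no comparable step, the expectation rests on compound 2 alone; the step of a 1.6-fold lower number from compound 2 to compound 3 (0.20 log units; within the scatter) is expected to stay within the usual scatter, if anything a little toward stronger growth inhibition. Compound 3 is therefore expected to give about 12000 nM in this assay, within a range from 4000 nM to 35000 nM.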

Compound 3, concentration for 50% growth inhibition: 75000 nM
Compound 3: the middle estimate sits 6.3-fold (0.80 log units) below what was measured; the measured number lies above the stated range.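

In this assay, among these compounds, the exchange of methyl for chloro on an aromatic carbon, para to a large group, gives a 3.9-fold higher number from compound 2 to compound 3 (0.60 log units; beyond the scatter), which is the first step measured at this position, and it runs toward weaker inhibition of growth. The position therefore responds to a small change: the two groups match in what can be counted, each with a single heavy atom, no ring, no hydrogen-bond donors or acceptors and no net charge, yet the step lies beyond the scatter. Nothing in the data shown accounts for this step.

Going by these compounds, with a single step at this position, no trend across substituents can be drawn, and it remains open whether an amine, a methoxy group, a carboxylic acid or a plain hydrogen in the same place would give a number nearer to that of compound 2 or to that of compound 3. Also open, on these data alone, is whether the same exchange would shift growth inhibition in the same direction on another core or in another cell line.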